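Trifluoromethyl for ethyl on an aryl sulfonate ester

This account rests on a few compounds, and the source may have more. Where it says the series, first, only, none or still open, it means among the compounds named here.

Measured compounds:
compound 1, `Ic1ccc(Cn2ccnc2)cc1`, 730 nM
compound 2, `CCc1ccc(S(=O)(=O)Oc2ccc(Cn3ccnc3)cc2)cc1`, 110 nM

In an assay for inhibition of steroid 17-alpha-hydroxylase/17,20 lyase (Rattus norvegicus), using microsomes (a lower number here means a stronger inhibitor, a higher number a weaker inhibitor), compound 2 gives the lowest of the two numbers recorded, and compound 1 sits at a higher number, beyond the usual scatter. Compound 3, `O=S(=O)(Oc1ccc(Cn2ccnc2)cc1)c1ccc(C(F)(F)F)cc1`, differs from compound 2 only in the group on the aromatic carbon para to a large group: trifluoromethyl in place of ethyl on an aromatic carbon. For the measured compounds named here, with no comparable step among the measured compounds, the expected step of a 1.2-fold higher number from compound 2 to compound 3 (0.07 log units; within the scatter) is judged to lie within the scatter, in no firm direction. Compound 3 is therefore estimated at 130 nM, between 50 nM and 350 nM.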

Compound 3, half-maximal inhibitory concentration: 1040 nM
The estimate for compound 3 lay 8.0-fold (0.90 log units) below the measured number; the whole stated range lies below it.
By their numbers in this assay, from the lowest: compound 2; then compounds 1 and 3 (each within the scatter of the next).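

In this assay, trifluoromethyl in place of ethyl on the aromatic carbon para to a large group brings a 9.5-fold higher number from compound 2 to compound 3 (0.98 log units; beyond the scatter) and so shows that this position is sensitive to the exchange. Of the two groups, ethyl gives the stronger inhibitor here, a reading that rests on this single pair. No measurement shown bears on why the number rises. The compounds shown leave open how a methoxy group, an amine or a longer chain would read on the same carbon. They also leave open whether ethyl itself is favoured or trifluoromethyl alone is disfavoured.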